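Two limits and one open ester

A few compounds are considered here, and "the series" means these few. Any claim that something is new, unique, unknown or untested is made for them only; others in the source may bear on it.

Compound 1 `Nc1nc(N)c(CCCNc2cc(F)ccc2[N+](=O)[O-])c(O)n1`: > 100000 nM (a limit)
Compound 2 `Nc1nc(N)c(CCCN(Cc2ccc(NC(CCC(=O)O)C(=O)O)cc2)c2cc(F)ccc2[N+](=O)[O-])c(O)n1`: > 100000 nM (a limit)

Both compounds were tested in a functional assay on CCRF-CEM cells (Homo sapiens) for cytotoxicity, in the absence of a further agent; a higher number here means a weaker inhibitor, a lower number a stronger inhibitor. There, compound 2 gives > 100000 nM, which is a limit of the assay and not a number. The picture so far is the limit of > 100000 nM in this assay, at which 2 of the 2 values shown sit, so compound 2 has no exact value to compare against.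

Compound 3 `COC(=O)c1ccc(CN(CCCc2c(N)nc(N)nc2O)c2cc(F)ccc2[N+](=O)[O-])cc1` changes compound 2 in one place: methoxycarbonyl in place of (1,3-dicarboxypropyl)amino on an aromatic carbon. Among the measured compounds shown here, no measured pair of compounds shows what this change does. For the measured compounds named here, the only guide is compound 2 with its limit of > 100000 nM. The step expected in this assay is a number no higher from compound 2 to compound 3 (the limit leaves the size open), which means no clear move in either direction beyond the scatter. For compound 3 the estimate is 100000 nM, with an expected range from 40000 nM to 200000 nM.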

Compound 3, half-maximal inhibitory concentration: 55000 nM
Beside the measured number, compound 3's estimate is 1.8-fold (0.26 log units) above it; low and high end bracket the measured number.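

In this assay, among the compounds shown here, compound 3 is the first compound here with an exact value, so the series now has a number to work from and not only the limit of the test: the limit of > 100000 nM in this assay, at which 2 of the 3 values shown sit. Methoxycarbonyl in place of (1,3-dicarboxypropyl)amino on the aromatic carbon gives an at least 1.8-fold lower number from compound 2 to compound 3 (0.25 log units; that floor lies within the scatter), and 4-(methoxycarbonyl)benzyl in place of hydrogen on the nitrogen gives an at least 1.8-fold lower number from compound 1 to compound 3 (0.25 log units; that floor lies within the scatter). On these data alone, compound 1 and compound 2 both carry limits, so each step is only a floor and the true size of either change remains unknown.

As far as these compounds go, it remains open whether a nitrile or an amide at this aromatic carbon would also give an exact value. Also open, from the compounds shown here alone, is whether a longer chain in place of the methyl of the ester would shift the number beyond the scatter.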